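Cyclopentyl for Phenethyl in a Series Without Measured Toxicity

This account rests on a few compounds, and the source may have more. Where it says the series, first, only, none or still open, it means among the compounds named here.

Three compounds on a shared core were tested in a toxicity assay on THP-1 cells (Homo sapiens) for inhibition; on this read-out higher numbers stand for lower toxicity in this test and lower numbers for higher toxicity in this test. Compound 1 `COc1ccc(-c2cnc(NC(=O)c3cccc([N+](=O)[O-])c3)n2C)cc1` gives > 100000 nM, which is a limit of the assay and not a number. Compound 2 `COc1ccc(-c2cnc(NC(=O)CCc3ccccc3)n2C)cc1` gives > 100000 nM, again only a limit. Compound 3 `COc1ccc2c(c1)nc(NC(=O)c1ccc(F)cc1)n2C` gives > 100000 nM, also a limit. Going by the values given here, no step between measured compounds can be drawn from these. Compound 4 `COc1ccc(-c2cnc(NC(=O)C3CCCC3)n2C)cc1` is not yet measured; it differs from compound 2 by cyclopentyl in place of phenethyl on a carbonyl carbon. Because every measured value sits at the limit of > 100000 nM in this assay, at which 3 of the 3 values shown sit, no step beyond the usual scatter is expected in this assay in either direction. Compound 4 is expected to give about 100000 nM, between 50000 nM and 300000 nM, most likely again reported only as a limit. The expected step of a number no higher from compound 2 to compound 4 (the limit leaves the size open) is essentially none.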

Compound 4, half-maximal cytotoxic concentration: > 100000 nM
Compound 4 ended at the assay's limit (the forecaster's own chance of this, stated with the estimate: 85%); the middle value sits exactly at the limit.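

Going by these compounds alone, no step from compound 2 to compound 4 can be read in this assay because both values are limits and not numbers: the limit of > 100000 nM in this assay, at which 4 of the 4 values shown sit.

The compounds shown leave open whether any compound on this shared core has a toxicity that can be given as a number.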